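The compounds below may be only part of what the source reports. "The series", "measured", "known", "first", "only" and "open" are said of these compounds alone.

Working notes on the series. Compound 1 `Cc1cccc(-c2n[nH]cc2N2CCCNCC2)c1` carries methyl on an aromatic carbon of a six-membered aromatic ring of carbon only, meta to a large group; in an assay on isolated protein for binding affinity to 5-hydroxytryptamine receptor 6 (Homo sapiens) (a higher number here means a weaker inhibitor, a lower number a stronger inhibitor), compound 1 gives 636 nM. Compound 2 `Fc1cccc(-c2n[nH]cc2N2CCCNCC2)c1` has fluoro at that same place, and in this assay compound 2 gives 841 nM. The change between the two is methyl in place of fluoro on an aromatic carbon, and the step it made is a 1.3-fold lower number from compound 2 to compound 1 (0.12 log units; within the scatter).

Compound 3 `Fc1ccc(-c2n[nH]cc2N2CCNCC2)cc1` rests on a different core; the difference between the two cores is not broken down here. In this assay, among the compounds with values here, compound 3 gives 373 nM, the lowest of the three numbers so far. Its gap to compound 2 lies beyond the scatter, whereas compound 1 sits within the scatter of compound 3, so no order between compound 3 and compound 1 is claimed.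

Compound 4 `Cc1ccc(-c2n[nH]cc2N2CCNCC2)cc1` is not yet measured. It differs from compound 3 by methyl in place of fluoro on an aromatic carbon. This is the same kind of change as that from compound 2 to compound 1, but not the same: there the place was meta to a large group, here it is para to a large group. In this assay, within the data shown here, only a single instance of this kind of change is available, and it stayed within the scatter: a 1.3-fold lower number from compound 2 to compound 1 (0.12 log units; within the scatter). On that basis a small step from compound 3 to compound 4 is expected. The step meant by this estimate, a 1.2-fold lower number from compound 3 to compound 4 (0.09 log units; within the scatter), is expected to remain within the scatter. Compound 4 is thus expected to give 300 nM in this assay, with the estimate spanning 150 nM to 650 nM.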

Compound 4, inhibition constant: 653 nM
Beside the measured number, compound 4's estimate is 2.2-fold (0.34 log units) below it; measured number outside the range, above it.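

In this assay, within the data shown here, the new step is a 1.8-fold higher number from compound 3 to compound 4 (0.24 log units; within the scatter), so methyl in place of fluoro, here para to a large group, gives no step that can be told apart from the scatter on this core. Set beside the earlier instance, the two steps show no difference that can be read: the same change on two cores in this assay, a 1.3-fold lower number (0.12 log units; within the scatter) from compound 2 to compound 1 and a 1.8-fold higher number (0.24 log units; within the scatter) from compound 3 to compound 4, 2.3-fold (0.36 log units) apart, within the scatter of two such steps. This supports only the statement that the change stayed small on both cores; with just two pairs, which also differ in the place of the group (meta to a large group in one, para to a large group in the other), it shows neither that the change carries over unaltered nor that core or place alters it, and the opposite directions of the two steps are not to be read as a reversal.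

The compounds shown carry only fluoro or methyl on the aromatic ring, so it stays open how other groups, such as methoxy, a nitrile or an amine, would read in this assay. Also open, from the compounds shown here alone, is whether the two places, meta to a large group and para to a large group, would read alike on one and the same core.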